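The source may report more compounds than this note shows. Statements on the series, on what has been measured and on what is new or still open speak of the compounds shown alone.

In a functional assay on KYSE-410 cells (Homo sapiens) for antiproliferative activity, read by MTT assay, with a stated time of 72 h (a higher number here means a weaker inhibitor, a lower number a stronger inhibitor), compound 1 (`O=C(c1ccnc2cc(Br)ccc12)N1CCCCC1`) gives > 20000 nM as a limit of the assay and not a number. Compound 2 (`COc1ccc(NC(=O)c2cc(=O)[nH]c3cc(Br)ccc23)cc1`) gives > 20000 nM as a limit as well. Compound 3 (`O=C(Nc1cc(F)ccc1F)c1cc(=O)[nH]c2cc(Br)ccc12`) gives > 20000 nM as a further limit. Compound 2 therefore has no numerical value and stands with the other two at the limit of > 20000 nM in this assay, at which 3 of the 3 values shown sit, in this assay. Compound 4 (`O=C(Nc1ccc(C(F)(F)F)cc1)c1cc(=O)[nH]c2cc(Br)ccc12`) is not yet measured and differs from compound 2 by trifluoromethyl in place of methoxy on an aromatic carbon, para to a large group (trifluoromethyl in place of methoxy on an aromatic carbon). Within the data shown here, no measured step is available, so no change beyond the scatter is expected. The expected change is a number no higher from compound 2 to compound 4 (the limit leaves the size open) in this assay on this reading. For compound 4 the estimate is 20000 nM with 7000 nM to 40000 nM as the expected range.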

Compound 4, half-maximal inhibitory concentration: > 20000 nM
Compound 4: a limit, no number (the forecaster's own chance of this, stated with the estimate: 65%); the middle value lies on the limit itself.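

Compound 2 and compound 4 give no readable step in this assay, as both values are limits of the assay and not numbers: the limit of > 20000 nM in this assay, at which 4 of the 4 values shown sit. The compounds shown leave open how far trifluoromethyl and methoxy differ in this series, and which change to the shared core would give a numerical value in this assay.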